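The compounds below may be only part of what the source reports. "The series", "measured", "known", "first", "only" and "open" are said of these compounds alone.

Going by the values given here, compound 1 `Cc1n[nH]c2ccc(-c3nc4cnc(N5CCN(C)CC5)cn4c3Nc3ccc(Cl)cc3)cc12` gives 83.7% in a functional assay on MV4-11 cells (Homo sapiens) for inhibition, with a stated time of 120 h, tested at 10 uM (on this read-out higher numbers stand for more inhibition at the one concentration tested (going by the name of the read-out) and lower numbers for less inhibition), the highest of the three numbers measured so far. Compound 2 `Cc1n[nH]c2ccc(-c3nc4cnc(N5CCC(C)CC5)cn4c3Nc3ccc(Cl)cc3)cc12` gives 28% in this assay, and compound 3 `Cc1n[nH]c2ccc(-c3nc4cnc(N5CCN(C)CC5)cn4c3Nc3ccc(Br)cc3Cl)cc12` gives 70.5%. Compound 4 `Cc1cc(Br)ccc1Nc1c(-c2ccc3[nH]nc(C)c3c2)nc2cnc(N3CCN(C)CC3)cn12` has not yet been measured in this assay; it differs from compound 1 by 4-bromo-2-methylphenyl in place of 4-chlorophenyl on a nitrogen on an aromatic ring. Of the measured steps, only a number 13.2 percentage points lower from compound 1 to compound 3 (beyond the scatter) bears on this change, since it likewise replaces the 4-chlorophenyl on the nitrogen with a ring carrying a bromine and a second substituent; the step of a number 55.7 percentage points lower from compound 1 to compound 2 (beyond the scatter) alters another part of the molecule and offers no guidance here. A modest fall is therefore expected for compound 4, a number 13.7 percentage points lower from compound 1 to compound 4 (beyond the scatter). Compound 4 is estimated at 70%, most likely between 55% and 85%.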

Compound 4, a percentage reported as inhibition, at one concentration (the size of the read-out at that concentration, not a potency): 59.4%
Beside the measured number, compound 4's estimate is 10.6 percentage points above it, and the stated range covers the measured number.
By their numbers in this assay, from the lowest: compound 2; then compound 4; then compound 3; then compound 1.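

With a number 24.3 percentage points lower from compound 1 to compound 4 (beyond the scatter) in this assay, a second ring bearing bromine again gives less inhibition than the 4-chlorophenyl on this nitrogen, as compound 3 also did. The new point is that the other substituent counts: methyl in place of chloro on an aromatic carbon, with bromine retained, gives a number 11.1 percentage points lower from compound 3 to compound 4 (beyond the scatter). Nothing available here accounts for either step. The compounds shown do not separate the contribution of bromine from that of the added group, since plain 4-bromophenyl is absent. On these data alone, whether a methoxy or an amine in place of that methyl would recover inhibition also remains open.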